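A few compounds are considered here, and "the series" means these few. Any claim that something is new, unique, unknown or untested is made for them only; others in the source may bear on it.

Measured so far in an ADME assay on A549 cells (Homo sapiens) for cytotoxicity, read by resazurin assay, with a stated time of 48 h; a higher number here means that more compound is tolerated, a lower number that less compound is tolerated:
- Compound 1 `O=C(Nc1ccc(NCc2ccc(C(F)(F)F)cc2)cc1Cl)c1cc(Cl)ccc1O`: 62700 nM
- Compound 2 `COc1ccc(CNc2ccc(NC(=O)c3cc(Cl)ccc3O)c(Cl)c2)cc1`: 80700 nM
- Compound 3 `O=C(Nc1ccc(NCc2ccc(O)cc2)cc1Cl)c1cc(Cl)ccc1O`: 116000 nM

These three compounds share one core and differ in a single group: trifluoromethyl in compound 1, methoxy in compound 2 and hydroxy in compound 3. Compound 3 cannot be separated from the other two on these numbers. The smaller gap is a 1.4-fold higher number from compound 2 to compound 3 (0.16 log units; within the scatter), and the larger is a 1.9-fold higher number from compound 1 to compound 3 (0.27 log units; within the scatter).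

Compound 4 `CN(C)c1ccc(CNc2ccc(NC(=O)c3cc(Cl)ccc3O)c(Cl)c2)cc1` keeps the core of compound 3 but carries dimethylamino in place of hydroxy on an aromatic carbon, para to a large group: dimethylamino in place of hydroxy on an aromatic carbon. Within the data shown here, no measured compound carries dimethylamino, so the data do not test this change directly. The nearest guides are the swaps already made at this same place. Besides the two steps to compound 3, there is a 1.3-fold higher number from compound 1 to compound 2 (0.11 log units; within the scatter). All three stay within the scatter, so no step beyond the scatter is expected in this assay, and no direction can be firmly predicted.

The estimate is placed among the three measured values, and the expected step is a 1.4-fold lower number from compound 3 to compound 4 (0.14 log units; within the scatter). For compound 4 the estimated value is 84000 nM, with an expected range from 48000 nM to 140000 nM.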

Compound 4, half-maximal cytotoxic concentration: 24500 nM
Compound 4: the middle estimate sits 3.4-fold (0.54 log units) above what was measured, and the stated range ends above it.
By their numbers in this assay, from the lowest: compound 4; then compounds 1, 2 and 3 (each within the scatter of the next).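

In this assay, this position had looked indifferent to what it carried, since trifluoromethyl, methoxy and hydroxy all gave values within the scatter of one another. Dimethylamino is the first group here to move the number beyond the scatter, with a 4.7-fold lower number from compound 3 to compound 4 (0.68 log units; beyond the scatter), a 3.3-fold lower number from compound 2 to compound 4 (0.52 log units; beyond the scatter) and a 2.6-fold lower number from compound 1 to compound 4 (0.41 log units; beyond the scatter), so all three steps point the same way, though each is modest, and compound 4 stands apart as the least tolerated of the four. The position can therefore respond to a change of group, but nothing available here explains why dimethylamino differs from the other three groups.

The compounds shown leave open whether the lower number goes with the nitrogen itself or with its two methyl groups, a question that a plain amino group or a methylamino group at the same place would help to answer. They also leave open whether other groups holding nitrogen, such as a longer diethylamino group or a morpholine ring, or a carboxylic acid, would follow compound 4 or stay with the other three.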